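This account rests on a few compounds, and the source may have more. Where it says the series, first, only, none or still open, it means among the compounds named here.

Compound 1, `COc1cc(-c2nn(-c3cccc(NC(=O)Nc4ccc(Cl)c(Cl)c4)c3)cc2-c2ccncc2)ccc1Cl`: in a functional assay on M14 cells (Homo sapiens) for inhibition, read by sulforhodamine B assay, with a stated time of 48 h (on this read-out lower numbers stand for stronger inhibition of growth and higher numbers for weaker inhibition of growth), compound 1 gives 2690 nM.
Compound 2, `COc1cc(-c2nn(-c3cccc(NC(=O)c4ccc(Cl)c(C(F)(F)F)c4)c3)cc2-c2ccncc2)ccc1Cl`: in this assay compound 2 gives only a limit, > 32500 nM, not a number.

Compound 2 thus stands at the edge of what this assay reports, at the limit of > 32500 nM in this assay, at which 1 of the 2 values shown sits. Within the data shown here, the one measured step, an at least 12-fold higher number from compound 1 to compound 2 (1.08 log units; beyond the scatter), changed the group on the carbonyl carbon and pushed the read-out past that limit. Compound 3, `COc1cc(-c2nn(-c3cccc(NC(=O)c4ccccc4)c3)cc2-c2ccncc2)ccc1Cl`, differs from compound 2 in one place: phenyl in place of 4-chloro-3-(trifluoromethyl)phenyl on a carbonyl carbon. Among the measured compounds shown here, no measured step covers this particular swap, so the only guidance is that the amide bearing a substituted phenyl in compound 2 sits at the limit. The step from compound 2 to compound 3 is therefore expected to be small or none beyond the scatter, an at least 1.3-fold lower number from compound 2 to compound 3 (0.11 log units; that floor lies within the scatter). For compound 3 the estimate in this assay is 25000 nM, with a range from 5000 nM to 100000 nM, and a fair chance that again only a limit is reported.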

Compound 3, concentration for total growth inhibition: 12900 nM
Estimate against measurement, compound 3: 1.9-fold (0.29 log units) above; the measured number falls inside the stated range.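

On the carbonyl carbon, the unsubstituted phenyl gives an at least 2.5-fold lower number from compound 2 to compound 3 (0.40 log units; beyond the scatter), so in this assay the amide of compound 3 inhibits growth more strongly than the one carrying 4-chloro-3-(trifluoromethyl)phenyl. For compound 2, > 32500 nM is a limit of the assay and not a number. Even so, the plain phenyl amide does not match the (3,4-dichlorophenyl)amino group, as a 4.8-fold higher number from compound 1 to compound 3 (0.68 log units; beyond the scatter) shows, and compound 1 remains the strongest of the three.

The compounds shown do not separate the chlorine from the trifluoromethyl in the loss seen with compound 2, and a phenyl carrying only one of them would address this. They also leave open whether the nitrogen or the chlorines set compound 1 apart, which a plain phenylamino group on the carbonyl carbon would help to settle.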